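Replacing a 2-aminoethyl chain with phenyl in a cytotoxic series

The source may hold more compounds than are shown below. What is called first, only, known or untested is meant among the compounds shown, and "the series" means these compounds.

Compound 1 `NCCCNc1c(C(=O)NCc2ccc(F)cc2)nc(Br)c2cccnc12`: 5000 nM
Compound 2 `COc1cccc(CNC(=O)c2nc(Br)c3cccnc3c2N[C@H]2CC[C@H](N)CC2)c1`: 7000 nM

In a functional assay on MDA-MB-435 cells (Homo sapiens) for cytotoxicity, read by MTT assay, with a stated time of 72 h (a higher number here means a weaker inhibitor, a lower number a stronger inhibitor), compound 1 gives the lower of the two numbers, though compound 2 with 7000 nM sits within the scatter of it, so neither can be called the stronger. Compound 3 `O=C(NCc1ccc(F)cc1)c1nc(Br)c2cccnc2c1NCc1ccccc1` has not been measured in this assay. It differs from compound 1 by phenyl in place of 2-aminoethyl on a saturated chain carbon bound to a nitrogen on an aromatic ring. For the measured compounds named here, no measured pair shows this change, so its effect is unknown. A modest step toward a lower number is expected, estimated as a 1.7-fold lower number from compound 1 to compound 3 (0.22 log units; within the scatter), so that compound 3 is expected to give 3000 nM, within 800 nM to 12000 nM.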

Compound 3, half-maximal inhibitory concentration: > 20000 nM
Compound 3 gave a limit, no number (the forecaster's own chance of this, stated with the estimate: 10%); middle value at least 6.6-fold (0.82 log units) away from the limit.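

In this assay, phenyl in place of 2-aminoethyl on a saturated chain carbon bound to a nitrogen on an aromatic ring gives an at least 4.0-fold higher number from compound 1 to compound 3 (0.60 log units; beyond the scatter). Compound 3 carries a limit of the assay and not a number: the limit of > 20000 nM in this assay, at which 1 of the 3 values shown sits. This position therefore does not tolerate every group, and among the compounds shown, only compound 3 has no amine on this chain.

Going by these compounds, whether the missing amine or the added ring matters more stays open, as both change in this one step. A plain propyl chain, or a benzyl group bearing an aminomethyl group, would separate the two.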